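Thiosemicarbazone series: aryl group and growth inhibition

A few compounds are considered here, and "the series" means these few. Any claim that something is new, unique, unknown or untested is made for them only; others in the source may bear on it.

Among the compounds with values here, compound 2 `CC1=CC[C@@H]([C@@](C)(O)CCCC(C)(C)NC(=S)N/N=C\c2ccc(O)cc2)CC1` holds the lowest of the two numbers so far in a functional assay on PCO3 cells (Homo sapiens) for cytotoxicity, read by sulforhodamine B assay; a lower number here means a stronger inhibitor of growth, a higher number a weaker inhibitor of growth: compound 2 gives 13900 nM, whereas compound 1 `CC1=CC[C@@H]([C@@](C)(O)CCCC(C)(C)NC(=S)N/N=C\c2ccccc2)CC1` gives 36200 nM. Within the data shown here, the one step at hand, a 2.6-fold lower number from compound 1 to compound 2 (0.42 log units; beyond the scatter), covers the hydroxy alone. Among the measured compounds shown here, compound 3 `CC1=CC[C@@H]([C@@](C)(O)CCCC(C)(C)NC(=S)N/N=C\c2cccc([N+](=O)[O-])c2)CC1` carries 3-nitrophenyl in place of 4-hydroxyphenyl on a carbon with a double bond to nitrogen, so the hydroxy is lost and a nitro comes in; no measured step covers a nitro. Losing the hydroxy points back toward compound 1, so compound 3 is expected to show a 1.8-fold higher number from compound 2 to compound 3 (0.25 log units; within the scatter). The estimate for compound 3 in this assay is 25000 nM, within 9000 nM to 70000 nM.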

Compound 3, concentration for total growth inhibition: 20700 nM
Compound 3: the middle estimate sits 1.2-fold (0.08 log units) above what was measured, within the range that was stated.
By their numbers in this assay, from the lowest: compounds 2, 3 and 1 (each within the scatter of the next, the first and the last beyond it).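

In this assay the 3-nitrophenyl group on the carbon with a double bond to nitrogen separates from neither other aryl group: the data give a 1.5-fold higher number from compound 2 to compound 3 (0.17 log units; within the scatter) and also a 1.7-fold lower number from compound 1 to compound 3 (0.24 log units; within the scatter) for the nitro alone. So far, only the hydroxy gives a step beyond the scatter at this ring, and a nitro does not. Nothing at hand accounts for this difference between the two groups.

Since 3-nitrophenyl and 4-hydroxyphenyl differ in both group and ring position, the two effects remain unseparated. From the compounds shown here alone, an amine or a carboxylic acid on the aromatic ring remains open.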